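Amide-nitrogen substituent and maximal response in the series

The compounds below may be only part of what the source reports. "The series", "measured", "known", "first", "only" and "open" are said of these compounds alone.

Measured so far:
compound 1 `Cc1nc(N)sc1CCCN/C(N)=N/C(=O)N[C@@H](C)c1ccccc1` — 1.08
compound 2 `CCCCCCNC(=O)/N=C(\N)NCCCc1sc(N)nc1C` — 0.95

Compound 2 gives the lower of the two numbers in a functional assay on Right cardiac atrium for agonist activity at histamine H2 receptor (Cavia porcellus), with a stated time of 30 min, in the presence of a further agent that is not named here; a lower number here means a smaller maximal response, a higher number a larger maximal response; compound 1 sits a number 0.13 lower from compound 1 to compound 2 (beyond the scatter), a step beyond the scatter. Both compounds share the same core and differ only at the amide-type nitrogen.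

Compound 3 `Cc1nc(N)sc1CCCN/C(N)=N/C(=O)NC(C)c1ccco1` carries the change (1-(furan-2-yl)ethyl in place of hexyl on an amide-type nitrogen). For the measured compounds named here, this change runs opposite to the one measured step: where compound 2 lost a branched aryl-bearing group for a straight chain, compound 3 brings in a branched group with a five-membered aromatic ring in place of the chain. Going by the values given here, the only step that bears on it is a number 0.13 lower from compound 1 to compound 2 (beyond the scatter), and a step of about that size in the opposite direction is expected here, giving a number 0.090 higher from compound 2 to compound 3 (within the scatter).

Compound 3 is therefore estimated at 1.04 in this assay, with a range of 0.93 to 1.14.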

Compound 3, intrinsic activity: the largest response reached, as a fraction of the reference agonist's: 1
The estimate for compound 3 lay 0.040 above the measured number; low and high end bracket the measured number.
By their numbers in this assay, from the lowest: compounds 2, 3 and 1 (each within the scatter of the next, the first and the last beyond it).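

In this assay the step to 1-(furan-2-yl)ethyl on the amide-type nitrogen is a number 0.050 higher from compound 2 to compound 3 (within the scatter) and the step from the other side is a number 0.080 lower from compound 1 to compound 3 (within the scatter). Compound 3 thus cannot be told apart from either compound 1 or compound 2, even though those two lie beyond the scatter of each other, so at this position the five-membered aromatic ring with its one hetero atom gives a maximal response that sides clearly with neither the 1-phenylethyl nor the hexyl group. Nothing available here explains this placing.

Open, going by these compounds, is whether the branching methyl matters, which a furan-2-ylmethyl or a benzyl group on the same nitrogen would test. Also open, on these data alone, is how a longer chain than hexyl, or a chain ending in an amine, would compare with these three.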